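Aromatic group swap from compound 3 to compound 4

A few compounds are considered here, and "the series" means these few. Any claim that something is new, unique, unknown or untested is made for them only; others in the source may bear on it.

- compound 1 `O=C(Cc1csc2nc(-c3ccc(Br)cc3)cn12)N/N=C/c1ccccc1O`: 11700 nM
- compound 2 `O=C(Cc1csc2nc(-c3ccc(Br)cc3)cn12)N/N=C/c1ccc(O)cc1`: 46800 nM
- compound 3 `COc1cccc(OC)c1/C=N/NC(=O)Cc1csc2nc(-c3ccc(Br)cc3)cn12`: 24500 nM

All three values come from a functional assay on SF-539 cells (Homo sapiens) for inhibition, read by sulforhodamine B assay, with a stated time of 48 h; a lower number here means a stronger inhibitor of growth, a higher number a weaker inhibitor of growth. Compound 3 sits at the upper end of this small set, together with compound 2. The step between those two is a 1.9-fold lower number from compound 2 to compound 3 (0.28 log units; within the scatter), while the step from the lowest number is a 2.1-fold higher number from compound 1 to compound 3 (0.32 log units; beyond the scatter).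

Compound 4 `O=C(Cc1csc2nc(-c3ccc(Br)cc3)cn12)N/N=C/c1ccc(Cl)cc1Cl` carries 2,4-dichlorophenyl in place of 2,6-dimethoxyphenyl on a carbon with a double bond to nitrogen.

For the measured compounds named here, all the measured steps bear on this change, since each one alters the group at the same place. The largest is a 4.0-fold higher number from compound 1 to compound 2 (0.60 log units; beyond the scatter), and it is only modest. Going by the values given here, no measured compound has a chlorine-bearing group here, so the data give no direction for this change. In this assay, no step beyond the scatter is therefore expected, although a modest move either way would fit the size of the step to compound 2 from compound 1 shown above.

The expected step is a 1.1-fold lower number from compound 3 to compound 4 (0.05 log units; within the scatter). For compound 4 the estimated value is 22000 nM, with an expected range from 9000 nM to 60000 nM.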

Compound 4, concentration for total growth inhibition: 63100 nM
For compound 4 the middle estimate is 2.9-fold (0.46 log units) below the measured one; measured number outside the range, above it.
By their numbers in this assay, from the lowest: compound 1; then compounds 3, 2 and 4 (each within the scatter of the next, the first and the last beyond it).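

In this assay, the only chlorine-bearing group shown at this position, on a carbon with a double bond to nitrogen, gives a number beyond the scatter of the 2,6-dimethoxyphenyl compound, with a 2.6-fold higher number from compound 3 to compound 4 (0.41 log units; beyond the scatter). The position therefore responds to a swap between two groups that both lack hydrogen-bond donors, so the absence of donors alone does not fix the number; against the 4-hydroxyphenyl group the step is a 1.3-fold higher number from compound 2 to compound 4 (0.13 log units; within the scatter), which leaves those two groups inseparable, while the 2-hydroxyphenyl group stays apart, with a 5.4-fold higher number from compound 1 to compound 4 (0.73 log units; beyond the scatter), now the largest step in the set. Nothing among the available data accounts for any of these steps.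

Open is whether the chlorine atoms themselves matter, since a phenyl group carrying a single chlorine, or a plain unsubstituted phenyl group, is not among the compounds shown. Also open, on these data alone, is how this position would respond to an aminophenyl or carboxyphenyl group, and whether the order of compounds 1 to 4 would hold with a different group in place of the bromine on the shared core.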